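Amide-ring swap on the sulfonylpiperidine carboxamide series

The source may hold more compounds than are shown below. What is called first, only, known or untested is meant among the compounds shown, and "the series" means these compounds.

Measured so far:
compound 1, `CCN(CC)S(=O)(=O)c1ccc(S(=O)(=O)N2CCC[C@@H](C(=O)N3CCC(O)CC3)C2)cc1`, 870 nM in a functional assay on MIA PaCa-2 cells (Homo sapiens) for inhibition, read by MTT assay, with a stated time of 7 days; on this read-out higher numbers stand for weaker inhibition and lower numbers for stronger inhibition
compound 2, `CCC(CC)S(=O)(=O)c1ccc(S(=O)(=O)N2CCC[C@@H](C(=O)N3CCC(F)(F)CC3)C2)cc1`, 13 nM
compound 3, `CN(C)S(=O)(=O)c1ccc(S(=O)(=O)N2CCC[C@@H](C(=O)N3CCC(F)(F)CC3)C2)cc1`, 118 nM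

Compound 1 stands at the highest of the three numbers in this assay: compound 3 lies lower, and compound 2 lowest. Compound 1 and compound 3 differ at two places, so their gap cannot be assigned to either one on its own. Among the compounds with values here, the only single step is a 9.1-fold higher number from compound 2 to compound 3 (0.96 log units; beyond the scatter), and it concerns the sulfonyl substituent, not the carbonyl-bound ring.

Compound 4, `CCN(CC)S(=O)(=O)c1ccc(S(=O)(=O)N2CCC[C@@H](C(=O)N3CC[C@H](OC)C3)C2)cc1`, is compound 1 with 3-methoxypyrrolidin-1-yl in place of 4-hydroxypiperidin-1-yl on a carbonyl carbon. Within the data shown here, no measured step touches the ring on the carbonyl carbon, so nothing here sets a direction for this change; the two rings match in heavy-atom count and the counted acceptor, and differ in ring size and the counted donor. The expectation is therefore a step within or only slightly beyond the scatter, a 1.6-fold lower number from compound 1 to compound 4 (0.20 log units; within the scatter), leaning toward a somewhat lower number. Compound 4 is estimated at 550 nM, expected between 150 nM and 2000 nM.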

Compound 4, half-maximal inhibitory concentration: 2460 nM
Estimate against measurement, compound 4: 4.5-fold (0.65 log units) below; the whole stated range lies below it.
By their numbers in this assay, from the lowest: compound 2; then compound 3; then compound 1; then compound 4.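

In this assay, the ring on the carbonyl carbon now has its first readable single step: 3-methoxypyrrolidin-1-yl in place of 4-hydroxypiperidin-1-yl gives a 2.8-fold higher number from compound 1 to compound 4 (0.45 log units; beyond the scatter). This position therefore responds to a swap that leaves the heavy-atom and acceptor counts unchanged, while ring size, the counted donor and the defined stereocentre all change together. No available evidence assigns the step to any one of these differences.

On these data alone, it remains open whether ring size or the hydroxyl-to-methoxy exchange carries the step, a question that 4-methoxypiperidin-1-yl and 3-hydroxypyrrolidin-1-yl on the core of compound 1 could separate. As far as these compounds go, the effect of the opposite configuration at the 3-methoxypyrrolidin-1-yl stereocentre also remains open.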